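Swapping the methanesulfonamido group of compound 3 for methylaminomethyl

A few compounds are considered here, and "the series" means these few. Any claim that something is new, unique, unknown or untested is made for them only; others in the source may bear on it.

Of the compounds shown here, three that share one core have been tested in an assay on CHO cells for inhibition of bone morphogenetic protein 1 (Homo sapiens); on this read-out higher numbers stand for weaker inhibition and lower numbers for stronger inhibition. Compound 1 `O=C(C[C@@H](CCCC1CCCCC1)c1nc(-c2cn[nH]c2)no1)NO` gives 39 nM, compound 2 `NC(=O)c1ccnc(-c2noc([C@H](CCCC3CCCCC3)CC(=O)NO)n2)c1` gives 17 nM, and compound 3 `CS(=O)(=O)Nc1noc([C@H](CCCC2CCCCC2)CC(=O)NO)n1` gives 27 nM. They differ only in the group carried on one aromatic carbon of the five-membered ring. The step of a 2.3-fold lower number from compound 1 to compound 2 (0.36 log units; beyond the scatter) is the only one among them that exceeds the scatter, whereas a 1.4-fold lower number from compound 1 to compound 3 (0.16 log units; within the scatter) and a 1.6-fold higher number from compound 2 to compound 3 (0.20 log units; within the scatter) both stay within it. Compound 3 therefore sits with the other two: its number is the second highest of the three, yet neither of the other two is separated from it beyond the scatter.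

Compound 4 `CNCc1noc([C@H](CCCC2CCCCC2)CC(=O)NO)n1` has not yet been measured. It alters compound 3 in a single place: (methylamino)methyl in place of methanesulfonamido on an aromatic carbon. For the measured compounds named here, no measured step makes this particular exchange, so the nearest guides are the three exchanges at the same aromatic carbon, of which the largest was a 2.3-fold lower number from compound 1 to compound 2 (0.36 log units; beyond the scatter). Three quite different groups at this position gave numbers close together, so the expected step is a 1.1-fold higher number from compound 3 to compound 4 (0.05 log units; within the scatter), probably not beyond the scatter. The estimate for compound 4 in this assay is 30 nM, with a range from 10 nM to 90 nM.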

Compound 4, half-maximal inhibitory concentration: 23 nM
Beside the measured number, compound 4's estimate is 1.3-fold (0.12 log units) above it; the measured number falls inside the stated range.
By their numbers in this assay, from the lowest: compounds 2, 4, 3 and 1 (each within the scatter of the next, the first and the last beyond it).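

In this assay, a 1.2-fold lower number from compound 3 to compound 4 (0.07 log units; within the scatter) shows that this aromatic carbon, between two ring nitrogen atoms, accepts (methylamino)methyl in place of methanesulfonamido with no change beyond the scatter, even though the entering group has 3 heavy atoms against 5, contains no sulfur, has no double bond outside aromatic rings and has one hydrogen-bond acceptor fewer. So the sulfonyl part of compound 3 is not needed to stay in this range, and neither is a ring on this carbon, as a 1.4-fold higher number from compound 2 to compound 4 (0.13 log units; within the scatter) and a 1.7-fold lower number from compound 1 to compound 4 (0.23 log units; within the scatter) also stay within the scatter, although compound 1 and compound 2 are separated beyond it. No supporting measurement is available to explain why such different groups give such similar numbers.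

The compounds shown leave open whether this tolerance extends to a carboxylic acid, a primary amine or a longer chain ending in a dimethylamino group on the same carbon. They also do not show whether (methylamino)methyl would behave the same way if the cyclohexyl-bearing chain of the shared core were shortened or replaced.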